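This account rests on a few compounds, and the source may have more. Where it says the series, first, only, none or still open, it means among the compounds named here.

Compound 1 `CC1CCN(C2CCN(S(=O)(=O)c3cccc(-c4ccccc4F)c3)CC2)CC1` — > 5000 nM
Compound 2 `CC1CCN(C2CCN(S(=O)(=O)c3ccc(Cl)c(Cl)c3)CC2)CC1` — > 5000 nM
Compound 3 `CC1CCN(C2CCN(S(=O)(=O)c3cncc(Br)c3)CC2)CC1` — > 10000 nM

In an ADME assay on HCT-116 cells (Homo sapiens) for cytotoxicity, read by CellTiter-Glo, with a stated time of 72 h (on this read-out higher numbers stand for weaker inhibition and lower numbers for stronger inhibition), compound 3 gives > 10000 nM, which is a limit of the assay and not a number, the line (the limit of > 10000 nM in this assay, at which 1 of the 3 values shown sits). Compound 1 likewise gives > 5000 nM, a limit. Compound 2 gives > 5000 nM, also a limit; these two sit at the limit of > 5000 nM in this assay, at which 2 of the 3 values shown sit. Hence the step that the two limits leave unreadable from compound 2 to compound 3 cannot be read. Compound 4 `COc1cccc(S(=O)(=O)N2CCC(N3CCC(C)CC3)CC2)c1` carries a single change from compound 3: 3-methoxyphenyl in place of 5-bromopyridin-3-yl on a sulfonyl sulfur. Within the data shown here, no measured step bears readably on this change, so no direction can be drawn from the data. The author therefore expects compound 4 to return a limit once more, estimated at 10000 nM within 5000 nM to 30000 nM, a step of a number no higher from compound 3 to compound 4 (the limit leaves the size open) that is expected to stay within the scatter.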

Compound 4, half-maximal inhibitory concentration: > 5000 nM
Compound 4: no number, only a limit; the forecaster's own chance of this, stated with the estimate: 85%; the middle value lies beyond the limit too.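

The steps to compound 4 from compound 1, compound 2 and compound 3 cannot be read, since all four results are limits and not numbers: the limit of > 5000 nM in this assay, at which 3 of the 4 values shown sit.

The compounds shown leave open whether any group on the sulfonyl sulfur changes the read-out at all.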